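The compounds below may be only part of what the source reports. "The series", "measured", "known", "first", "only" and "open" are said of these compounds alone.

Measured compounds:
- compound 1 `CN(C)c1ccc(C(=O)Nc2cccc(NC(=O)COc3ccc4c(c3)CCC(=O)N4)c2)cc1`: > 10000 nM
- compound 2 `COc1cc(OCC(=O)Nc2cccc(NC(=O)c3ccc(N(C)C)cc3)c2)ccc1C=O`: 3740 nM

In an assay on isolated protein for inhibition of Rho-associated protein kinase 1 (Homo sapiens), read by scintillation counting, radiometric assay and 33P incorporation, with a stated time of 40 min, in the presence of a further agent that is not named here (on this read-out lower numbers stand for stronger inhibition and higher numbers for weaker inhibition), compound 1 gives > 10000 nM, which is a limit of the assay rather than a number. For the measured compounds named here, compound 2 is the only compound with a number here; in this assay compound 2 gives 3740 nM. Going by the values given here, the one measured step, an at least 2.6-fold lower number from compound 1 to compound 2 (0.42 log units; beyond the scatter), can only be stated as a lower bound because of the limit of > 10000 nM in this assay, at which 1 of the 2 values shown sits.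

Compound 3 `CC(=O)c1ccc(OCC(=O)Nc2cccc(NC(=O)c3ccc(N(C)C)cc3)c2)cc1F` is not yet measured. It differs from compound 2 at the same place that changed between compound 1 and compound 2: a group of 10 heavy atoms (8 carbon, 1 oxygen, 1 fluorine; one six-membered aromatic ring of carbon only) in place of a group of 10 heavy atoms (8 carbon, 2 oxygen; one six-membered aromatic ring of carbon only), on an oxygen on a saturated carbon. The group that enters in compound 3 is close in size to the group that leaves, and the measured step gives no guidance on swapping one such group for another. No step beyond the scatter is therefore expected; the estimated change is a 1.2-fold higher number from compound 2 to compound 3 (0.08 log units; within the scatter). Compound 3 is expected to give about 4500 nM, with a range from 1800 nM to 11000 nM.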

Compound 3, half-maximal inhibitory concentration: 445 nM
Beside the measured number, compound 3's estimate is 10-fold (1.00 log units) above it; the whole stated range lies above it.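

In this assay, the place on an oxygen on a saturated carbon responds strongly to a swap between two groups of equal heavy-atom count, each with one six-membered aromatic ring of carbon only, with an 8.4-fold lower number from compound 2 to compound 3 (0.92 log units; beyond the scatter) for the entry of 4-acetyl-3-fluorophenyl. Group size alone therefore does not settle the result at this place, which the first step could not show, since the groups in it differed in size and ring count. The wider step, an at least 22-fold lower number from compound 1 to compound 3 (1.35 log units; beyond the scatter), is only a lower bound because the value of compound 1 is a limit and not a number: the limit of > 10000 nM in this assay, at which 1 of the 3 values shown sits.

The compounds shown do not separate the part played by the acetyl from that of the fluorine. On these data alone, how a chlorine in place of that fluorine, or an amine or a carboxylic acid in place of the acetyl, would read also stays open.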